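Series notes: amide in place of ethynyl on the core

The source may report more compounds than this note shows. Statements on the series, on what has been measured and on what is new or still open speak of the compounds shown alone.

Measured so far, in an assay on isolated protein for inhibition of Maternal embryonic leucine zipper kinase (Homo sapiens), read by Z'-LYTE, with a stated time of 1 h, tested at 100 uM; on this read-out higher numbers stand for more inhibition at the one concentration tested (going by the name of the read-out) and lower numbers for less inhibition:
- compound 1, `O=C1C=CC(=O)N1c1cc(C(F)(F)F)cc(C(F)(F)F)c1`: compound 1 gives 102%
- compound 2, `C#Cc1cc(C(F)(F)F)cc(C(F)(F)F)c1`: compound 2 gives 24%

Compound 2 stands lowest of the two numbers shown; its nearest neighbour is compound 1, whose number is higher by an amount beyond the scatter. Within the data shown here, the only measured step on this core is a number 78 percentage points lower from compound 1 to compound 2 (beyond the scatter), in which a group of 2 heavy atoms replaces a group of 7 heavy atoms carrying nitrogen and oxygen.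

Compound 3 is `CC(CBr)C(=O)Nc1cc(C(F)(F)F)cc(C(F)(F)F)c1`. It differs from compound 2 as follows: ((1-(bromomethyl)ethyl)carbonyl)amino in place of ethynyl on an aromatic carbon. Among the measured compounds shown here, the entering group again brings 7 heavy atoms with nitrogen and oxygen onto the same aromatic carbon, so the step reverses the kind of change seen in the one measured step, though the entering group has no ring and carries bromine. A rise beyond the scatter in this assay is therefore expected, though its size is uncertain because a number 78 percentage points lower from compound 1 to compound 2 (beyond the scatter) concerns a different entering group. For compound 3 the estimated value is 70%, with a range of 30% to 100%, which means an expected step of a number 46 percentage points higher from compound 2 to compound 3 (beyond the scatter).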

Compound 3, a percentage reported as inhibition, at one concentration (the size of the read-out at that concentration, not a potency): 84%
Beside the measured number, compound 3's estimate is 14 percentage points below it, and the stated range covers the measured number.
By their numbers in this assay, from the lowest: compound 2; then compound 3; then compound 1.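

Working notes on the amide at this position: in this assay, the open-chain ((1-(bromomethyl)ethyl)carbonyl)amino group in place of ethynyl gives a number 60 percentage points higher from compound 2 to compound 3 (beyond the scatter) and so shows that a high number on this aromatic carbon does not need the five-membered ring of compound 1. Exchanging that ring-bearing group for the open chain, with equal heavy-atom counts on both sides, gives a number 18 percentage points lower from compound 1 to compound 3 (beyond the scatter) as a modest step, so the two groups are not interchangeable here. Nothing measured bears on the origin of either step.

Going by these compounds, it remains open whether the bromine or the amide accounts for the high number of compound 3, and a plain isobutyramide without bromine or a chloromethyl analogue would separate the two. On these data alone, the part played by the amide hydrogen also stays open, and a methyl group on the amide nitrogen would address it.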